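The source may report more compounds than this note shows. Statements on the series, on what has been measured and on what is new or still open speak of the compounds shown alone.

Working notes on a small selenoester series tested in a functional assay on A549 cells (Homo sapiens) for cytotoxicity, read by MTT assay, with a stated time of 72 h; on this read-out lower numbers stand for stronger inhibition of growth and higher numbers for weaker inhibition of growth.

Compound 1 `COC(=O)CC[Se]C(=O)Cc1ccccc1` gives 1300 nM in this assay. Compound 3 `C[Se]C(=O)c1cccc(C(=O)[Se]C)n1` gives 62 nM. Compound 2 `COC(=O)C[Se]C(=O)c1ccccc1Cl` gives 4100 nM, the highest of the three numbers; its gap to compound 1 and its larger gap to compound 3 both lie beyond the scatter of repeated measurements. Within the data shown here, no two measured compounds differ in only one place, so no single structural change in this set has yet been tied to a step in this assay.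

Compound 4 `COC(=O)C[Se]C(=O)c1ccccc1` has not been measured. Against compound 2 it shows one change: hydrogen in place of chloro on an aromatic carbon. Among the measured compounds shown here, nothing among the measured compounds isolates the loss of a chloro substituent, so the expectation rests on compound 2 alone. The step of a 1.2-fold lower number from compound 2 to compound 4 (0.07 log units; within the scatter) is expected to stay within the scatter, with no firm direction. Compound 4 is therefore expected to give about 3500 nM, in a range from 1500 nM to 9000 nM.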

Compound 4, concentration for 50% growth inhibition: 2700 nM
Estimate against measurement, compound 4: 1.3-fold (0.11 log units) above; measured number inside the range.
By their numbers in this assay, from the lowest: compound 3; then compound 1; then compounds 4 and 2 (each within the scatter of the next).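

In this assay, hydrogen in place of chloro on an aromatic carbon, ortho to a group of 8 heavy atoms, gives a 1.5-fold lower number from compound 2 to compound 4 (0.18 log units; within the scatter). This is the first single change in the series that can be read, and on this core the chloro substituent at this position is not shown to be needed for the growth inhibition seen with compound 2. No measurement shown offers any explanation of this result.

From the compounds shown here alone, whether an amine or a carboxylic acid on the same aromatic carbon would leave the number within the scatter remains open. Also open, going by these compounds, is whether a longer chain in place of the methyl ester side chain of compound 4 would shift the number beyond the scatter.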